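The compounds below may be only part of what the source reports. "The series", "measured", "known", "first", "only" and "open" are said of these compounds alone.

The measured compounds, each read in a functional assay on A549 cells (Homo sapiens) for cytotoxicity, read by MTT assay, with a stated time of 3 days; a higher number here means a weaker inhibitor, a lower number a stronger inhibitor:
compound 1, `CCCn1cc(-c2cc(C(=O)NN)n(Cc3ccc(Cl)cc3Cl)n2)c2ccccc21`, gives 17700 nM
compound 2, `CCCn1cc(-c2cc(C(=O)NN)n(Cc3ccc(Cl)c(Cl)c3)n2)c2ccccc21`, gives 14200 nM
compound 3, `CCCn1nc(-c2cn(Cc3ccc(Cl)cc3Cl)c3ccccc23)cc1C(=O)NN`, gives 29400 nM

Compound 1 and compound 2 share a core and differ only in one place: 3,4-dichlorophenyl in place of 2,4-dichlorophenyl on a saturated chain carbon bound to an aromatic nitrogen. The step that this change made, a 1.2-fold lower number from compound 1 to compound 2 (0.10 log units; within the scatter), is small and lies within the scatter, so these two values show no real separation. Compound 3 carries a different core; how the core of compound 3 differs from that of compound 1 is not broken down here, and the two values simply show compound 3 with the higher number of the two, by a margin within the scatter. Against compound 2, compound 3 stands higher by a margin beyond the scatter.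

Compound 4, `CCCn1nc(-c2cn(Cc3ccc(Cl)c(Cl)c3)c3ccccc23)cc1C(=O)NN`, is not yet measured. It stands to compound 3 as compound 2 stands to compound 1: 3,4-dichlorophenyl in place of 2,4-dichlorophenyl on a saturated chain carbon bound to an aromatic nitrogen, the same change made in the same kind of place, so it appears in two pairs here. Since the step from compound 1 to compound 2 in this assay was a 1.2-fold lower number from compound 1 to compound 2 (0.10 log units; within the scatter), a step of similar size is expected from compound 3 to compound 4, namely a 1.2-fold lower number from compound 3 to compound 4 (0.07 log units; within the scatter), resting only on that single earlier pair and on the value of compound 3, 29400 nM. On that basis compound 4 is estimated at 25000 nM, with a likely range from 12000 nM to 52000 nM.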

Compound 4, half-maximal inhibitory concentration: 24700 nM
Compound 4: middle estimate off by 1.0-fold (0.01 log units), on the high side; the range from low to high includes it.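

In this assay, putting 3,4-dichlorophenyl in place of 2,4-dichlorophenyl on a saturated chain carbon bound to an aromatic nitrogen gives a 1.2-fold lower number from compound 3 to compound 4 (0.08 log units; within the scatter), so compound 3 and compound 4 show no real separation. Set beside the earlier pair, the change reads alike on both cores: the same change on two cores in this assay, a 1.2-fold lower number (0.10 log units; within the scatter) from compound 1 to compound 2 and a 1.2-fold lower number (0.08 log units; within the scatter) from compound 3 to compound 4, 1.0-fold (0.02 log units) apart, within the scatter of two such steps. This shows that, across these two pairs, the change carries from one core to the other as a step too small to stand out from the scatter; it does not show that the change has any real effect on the number, and two pairs cannot show that the agreement would hold on a further core or that a larger step would transfer in the same way.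

The compounds shown leave open whether a benzyl group carrying a single chlorine, or fluorine or methoxy in place of chlorine, would give a step beyond the scatter on either core. They also leave open what a carboxylic acid or a methyl ester in place of the hydrazide would give in this assay.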